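Replacing quinolin-3-yl with 1-(methoxycarbonyl)piperidin-4-yl

The source may report more compounds than this note shows. Statements on the series, on what has been measured and on what is new or still open speak of the compounds shown alone.

In a physicochemical assay for solubility, in phosphate buffer, at pH 7.4 (on this read-out lower numbers stand for lower solubility and higher numbers for higher solubility), compound 1 (`OC1CN(c2nccnc2OC2CN(c3ccc4ccccc4n3)C2)C1`) gives 41000 nM. Compound 2 (`c1ccc2nc(N3CC(Oc4nccnc4N4CCCCC4)C3)ccc2c1`) gives < 1000 nM, which is a limit and not a number. Compound 3 (`c1ccc2ncc(-c3nccnc3OC3CN(c4ccc5ccccc5n4)C3)cc2c1`) gives < 1000 nM, which is likewise a limit.

The next structure, compound 4 (`COC(=O)N1CCC(c2nccnc2OC2CN(c3ccc4ccccc4n3)C2)CC1`), has not been measured. It carries 1-(methoxycarbonyl)piperidin-4-yl in place of quinolin-3-yl on an aromatic carbon, counted as 1-(methoxycarbonyl)piperidin-4-yl in place of quinolin-3-yl on an aromatic carbon.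

For the measured compounds named here, three measured steps bear on this change. Replacing 3-hydroxyazetidin-1-yl with piperidin-1-yl gave an at least 41-fold lower number from compound 1 to compound 2 (1.61 log units; beyond the scatter). Replacing it with quinolin-3-yl gave an at least 41-fold lower number from compound 1 to compound 3 (1.61 log units; beyond the scatter). Both steps are large, and both end at the limit of < 1000 nM in this assay, at which 2 of the 3 values shown sit. Exchanging piperidin-1-yl for quinolin-3-yl gives a step that the two limits leave unreadable from compound 2 to compound 3, so that comparison offers no size. None of the three steps introduces the entering group itself.

On the strength of an at least 41-fold lower number from compound 1 to compound 2 (1.61 log units; beyond the scatter), whose piperidin-1-yl also holds a non-aromatic six-membered ring, compound 4 is expected to stay near the limit in this assay rather than approach compound 1. Only a modest move toward higher numbers is expected, estimated as an at least 2.0-fold higher number from compound 3 to compound 4 (0.30 log units; that floor lies within the scatter). For compound 4 the estimate is 2000 nM, with an expected range from 700 nM to 10000 nM.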

Compound 4, solubility: 138000 nM
Compound 4: middle estimate off by 69-fold (1.84 log units), on the low side, and the stated range ends below it.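

In this assay, for the compounds shown here, the choice of group on this aromatic carbon of the six-membered aromatic ring with 2 nitrogen spans far more than the earlier compounds could show, as 1-(methoxycarbonyl)piperidin-4-yl gives an at least 130-fold higher number from compound 3 to compound 4 (2.13 log units; beyond the scatter) and an at least 130-fold higher number from compound 2 to compound 4 (2.13 log units; beyond the scatter), both of them floors set by a limit: the limit of < 1000 nM in this assay, at which 2 of the 4 values shown sit. A six-membered non-aromatic ring here therefore does not by itself hold the read-out at that limit, for the piperidin-1-yl of compound 2 sits there while the 1-(methoxycarbonyl)piperidin-4-yl of compound 4 does not. Going by these compounds alone, the 3-hydroxyazetidin-1-yl, the only group with a readable number until now, also proves not to mark the top of the range at this place, with a 3.4-fold higher number from compound 1 to compound 4 (0.53 log units; beyond the scatter).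

The compounds shown cannot separate the part played by the methoxycarbonyl from that of joining the ring through carbon in place of nitrogen. Going by these compounds, a piperidin-4-yl with a free ring amine, or an acetyl in place of the methoxycarbonyl, would bear on that question, and how either would read in this assay remains open.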